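The source may hold more compounds than are shown below. What is called first, only, known or untested is meant among the compounds shown, and "the series" means these compounds.

Compound 1 `COc1ccc2c(=O)c(/C=C/C(=O)NCc3ccccc3)coc2c1` stands lowest of the three numbers in an ADME assay on HepG2 2.2.15 cells (Homo sapiens) for cytotoxicity, read by MTT assay, with stated times of 48 h and 9 days (on this read-out lower numbers stand for higher toxicity in this test and higher numbers for lower toxicity in this test), where compound 1 gives 376000 nM. Compound 2 `COc1ccc2c(=O)c(/C=C/C(=O)Nc3ccccc3)coc2c1` gives 523000 nM and compound 3 `COc1ccc2c(=O)c(/C=C/C(=O)Nc3ccccc3Cl)coc2c1` gives 1010000 nM. Compound 4 `COc1ccc(NC(=O)/C=C/c2coc3cc(OC)ccc3c2=O)cc1` remains to be measured; it differs from compound 1 by 4-methoxyphenyl in place of benzyl on an amide-type nitrogen. The step bearing most directly on this change is a 1.4-fold higher number from compound 1 to compound 2 (0.14 log units; within the scatter), an aryl in place of the benzyl; a 1.9-fold higher number from compound 2 to compound 3 (0.29 log units; within the scatter) shows that chloro in place of hydrogen on an aromatic carbon moved the number little, and the combined a 2.7-fold higher number from compound 1 to compound 3 (0.43 log units; beyond the scatter) stayed modest. A small upward step, or none beyond the scatter, is therefore expected in this assay. Compound 4 is estimated at 520000 nM, within 260000 nM to 1050000 nM, corresponding to an expected 1.4-fold higher number from compound 1 to compound 4 (0.14 log units; within the scatter).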

Compound 4, half-maximal cytotoxic concentration: 718000 nM
Compound 4: the middle estimate sits 1.4-fold (0.14 log units) below what was measured, within the range that was stated.
By their numbers in this assay, from the lowest: compounds 1, 2, 4 and 3 (each within the scatter of the next, the first and the last beyond it).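

In this assay the 4-methoxyphenyl group on the amide-type nitrogen gives a 1.9-fold higher number from compound 1 to compound 4 (0.28 log units; within the scatter) against benzyl, so a second aryl group, after phenyl, stays within the scatter of benzyl, and only 2-chlorophenyl has gone beyond it. The change from phenyl to 4-methoxyphenyl gives a 1.4-fold higher number from compound 2 to compound 4 (0.14 log units; within the scatter) and 4-methoxyphenyl in place of 2-chlorophenyl gives a 1.4-fold lower number from compound 3 to compound 4 (0.15 log units; within the scatter) on this nitrogen, so the two substituted aryl groups cannot be told apart here. On these data alone, whether an amine, a carboxylic acid or a longer chain on this nitrogen would move the number beyond the scatter stays open. Nothing measured here gives a reason for these steps.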